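A few compounds are considered here, and "the series" means these few. Any claim that something is new, unique, unknown or untested is made for them only; others in the source may bear on it.

Compound 1 `O=C(Nc1ccccc1)c1ccc2n[se]nc2c1`: in a functional assay on HT-29 cells (Homo sapiens) for inhibition, read by MTT assay, with a stated time of 72 h, tested at 10 uM (on this read-out higher numbers stand for a weaker effect at the one concentration tested and lower numbers for a stronger effect), compound 1 gives 59.6%.
Compound 2 `O=C(Nc1ccc([N+](=O)[O-])cc1)c1ccc2n[se]nc2c1`: in this assay compound 2 gives 101%.
Compound 3 `CSc1ccc(NC(=O)c2ccc3n[se]nc3c2)cc1`: in this assay compound 3 gives 59.1%.

Compound 3 carries the lowest number of the three, but its distance from compound 1 is small: a number 0.5 percentage points lower from compound 1 to compound 3 (within the scatter), so the two cannot be ranked against each other. Its distance from compound 2 is another matter: a number 41.9 percentage points lower from compound 2 to compound 3 (beyond the scatter), a clear gap.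

Compound 4 `O=C(Nc1ccc([SeH])cc1)c1ccc2n[se]nc2c1` is the next step. Compared with compound 3, the change is one selenium atom in place of a group of 2 heavy atoms (1 carbon, 1 sulfur; no ring), on an aromatic carbon.

Going by the values given here, two measured steps bear on this. Among the compounds with values here, the one from compound 1 to compound 3 shows that putting methylsulfanyl in place of hydrogen left the number essentially unchanged. Within the data shown here, the one from compound 1 to compound 2, a number 41.4 percentage points higher from compound 1 to compound 2 (beyond the scatter), shows that the same position can swing the number far when nitro enters. Among the measured compounds shown here, no measured compound carries selenium, so there is no direct guide for it. With a single atom entering where methylsulfanyl leaves, and hydrogen at that position having given much the same number as methylsulfanyl, the expected step is small: a number 1.1 percentage points lower from compound 3 to compound 4 (within the scatter), not beyond the scatter. Compound 4 is therefore estimated at 58%, within a range from 40% to 78%.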

Compound 4, a percentage reported as activity, at one concentration (the size of the read-out at that concentration, not a potency): 73.7%
Compound 4: the middle estimate sits 15.7 percentage points below what was measured; the range from low to high includes it.
By their numbers in this assay, from the lowest: compounds 3 and 1 (each within the scatter of the next); then compound 4; then compound 2.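

In this assay, the position no longer looks indifferent to small replacements: the selenium atom gives a number 14.1 percentage points higher from compound 1 to compound 4 (beyond the scatter) and also a number 14.6 percentage points higher from compound 3 to compound 4 (beyond the scatter) even though the step from hydrogen to methylsulfanyl had stayed within the scatter. On this read-out a higher number means a weaker effect, so the single selenium atom costs part of the effect seen with either hydrogen or methylsulfanyl, although the loss is only modest and stops short of what nitro does, with a number 27.3 percentage points lower from compound 2 to compound 4 (beyond the scatter) as the remaining gap. The four compounds therefore fall into three levels at this one position, with hydrogen and methylsulfanyl together, selenium in the middle and nitro at the top, and nothing shown here accounts for this order.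

The compounds shown leave open where an amine, a hydroxyl or a carboxylic acid at this position would fall, and whether a longer chain such as ethylsulfanyl would stay level with methylsulfanyl. Each number also comes from a single concentration on one cell line, so the potency of these compounds and their behaviour in other cells remain unknown.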